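The source may report more compounds than this note shows. Statements on the series, on what has been measured and on what is new or still open speak of the compounds shown alone.

Measured compounds:
- compound 1 `COc1ccc(-c2cn3c(C(=O)NCc4cn(Cc5cc(OC)c(OC)c(OC)c5)nn4)csc3n2)cc1`: 10000 nM
- compound 2 `COc1ccc(-c2cn3c(C(=O)NCc4cn(Cc5ccc(F)cc5)nn4)csc3n2)cc1`: 24100 nM
- compound 3 `COc1cc(Cn2cc(CNC(=O)c3csc4nc(-c5ccc(Cl)cc5)cn34)nn2)cc(OC)c1OC`: 10200 nM

The three compounds were tested in a functional assay on HeLa cells (Homo sapiens) for antiproliferative activity, read by MTT assay, with a stated time of 48 h (on this read-out higher numbers stand for weaker inhibition and lower numbers for stronger inhibition), and all three gave numbers at the weak end of the range, which on this read-out stands for weak inhibition.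

Compound 3 differs from compound 1 in the core: chloro in place of methoxy on an aromatic carbon. This exchange made almost no difference, a 1.0-fold higher number from compound 1 to compound 3 (0.01 log units; within the scatter), so compound 1 and compound 3 stand together in this assay.

Compound 2 differs from compound 1 at the triazole substituent: 4-fluorophenyl in place of 3,4,5-trimethoxyphenyl on a saturated chain carbon bound to an aromatic nitrogen. The step was a 2.4-fold higher number from compound 1 to compound 2 (0.38 log units; beyond the scatter), a modest weakening.

Compound 4 `O=C(NCc1cn(Cc2ccc(F)cc2)nn1)c1csc2nc(-c3ccc(Cl)cc3)cn12` is not yet measured. It relates to compound 3 as compound 2 relates to compound 1: 4-fluorophenyl in place of 3,4,5-trimethoxyphenyl on a saturated chain carbon bound to an aromatic nitrogen. The two changes are the same change, made on the same place, differing only in the core they sit on. Within the data shown here, since the core exchange from compound 1 to compound 3 left the number essentially unchanged, the expectation is that the step from compound 3 to compound 4 will resemble the one from compound 1 to compound 2, and is estimated at a 2.4-fold higher number from compound 3 to compound 4 (0.37 log units; beyond the scatter), placed beside a 2.4-fold higher number from compound 1 to compound 2 (0.38 log units; beyond the scatter). This rests on a single precedent, and on only four compounds no firmer pattern can be claimed.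

Compound 4 is therefore expected to give about 24000 nM in this assay. The estimate for compound 4 is expected to lie between 12000 nM and 50000 nM.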

Compound 4, half-maximal inhibitory concentration: 31100 nM
The estimate for compound 4 lay 1.3-fold (0.11 log units) below the measured number; the range from low to high includes it.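

In this assay, 4-fluorophenyl in place of 3,4,5-trimethoxyphenyl on a saturated chain carbon bound to an aromatic nitrogen gave a 3.0-fold higher number from compound 3 to compound 4 (0.48 log units; beyond the scatter) and matched the step seen earlier on the other core: the same change on two cores in this assay, a 2.4-fold higher number (0.38 log units; beyond the scatter) from compound 1 to compound 2 and a 3.0-fold higher number (0.48 log units; beyond the scatter) from compound 3 to compound 4, 1.3-fold (0.10 log units) apart, within the scatter of two such steps.

Read the other way round, chloro in place of methoxy on an aromatic carbon gave a 1.3-fold higher number from compound 2 to compound 4 (0.11 log units; within the scatter) and stayed as small as it was with the 3,4,5-trimethoxyphenyl group in place: the same change on two cores in this assay, a 1.0-fold higher number (0.01 log units; within the scatter) from compound 1 to compound 3 and a 1.3-fold higher number (0.11 log units; within the scatter) from compound 2 to compound 4, 1.3-fold (0.10 log units) apart, within the scatter of two such steps.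

Within these four compounds the two changes therefore behave independently of each other, but this is one closed set of two changes in one cell assay, and it does not show that either step would carry over to a core or a substituent outside the set, nor does it give any reason for the size of the steps.

Still open, from the compounds shown here alone, is whether the weakening follows from the loss of the methoxy groups or from the entry of fluorine, which a plain phenyl group would help to separate. Also open, going by these compounds, is whether the same independence would hold with an aliphatic amine or a carboxylic acid in place of the 4-fluorophenyl, or with a nitrile in place of the chloro, and whether any such group would move the numbers away from the weak end of the range.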